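Series notes: methoxy in place of methyl, compound 4

This account rests on a few compounds, and the source may have more. Where it says the series, first, only, none or still open, it means among the compounds named here.

In an ADME assay on microsomes from liver (Homo sapiens) for metabolic stability, with a stated time of 10 min (on this read-out higher numbers stand for a more stable compound and lower numbers for a less stable compound), compound 3 `Cc1cccc(F)c1COC(c1ccc([C@]2(S(=O)(=O)c3ccc(F)cc3)CCN(C(=O)[C@H]3CC[C@H](C(=O)O)CC3)C2)cc1)(C(F)(F)F)C(F)(F)F` gives 79% and lies within the scatter of both compound 1 `O=C(O)C1CCN(C(=O)N2CC[C@](c3ccc(C(OCc4c(F)cccc4F)(C(F)(F)F)C(F)(F)F)cc3)(S(=O)(=O)c3ccc(F)cc3)C2)CC1` at 72% and compound 2 `Cc1cccc(C)c1COC(c1ccc([C@]2(S(=O)(=O)c3ccc(F)cc3)CCN(C(=O)[C@H]3CC[C@H](C(=O)O)CC3)C2)cc1)(C(F)(F)F)C(F)(F)F` at 89% without separating from either. Compound 4 `COc1cccc(F)c1COC(c1ccc([C@]2(S(=O)(=O)c3ccc(F)cc3)CCN(C(=O)[C@H]3CC[C@H](C(=O)O)CC3)C2)cc1)(C(F)(F)F)C(F)(F)F` carries methoxy in place of methyl on an aromatic carbon and so has 2-fluoro-6-methoxybenzyl where compound 3 has 2-fluoro-6-methylbenzyl. Going by the values given here, the one measured step at this place is a number 10 percentage points lower from compound 2 to compound 3 (within the scatter) for fluoro in place of methyl. Among the compounds with values here, it stays within the scatter, and no measured compound carries methoxy. No step beyond the scatter is therefore expected in this assay for this change. The expected move for compound 4 is a number 4 percentage points lower from compound 3 to compound 4 (within the scatter) and lies within the scatter. For compound 4 the estimate is 75% with 60% to 88% as the expected range.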

Compound 4, percent of the compound remaining: 82%
For compound 4 the middle estimate is 7 percentage points below the measured one; low and high end bracket the measured number.
By their numbers in this assay, from the lowest: compounds 1, 3, 4 and 2 (each within the scatter of the next, the first and the last beyond it).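

Methoxy, the first oxygen-bearing group at this position, gives a number 3 percentage points higher from compound 3 to compound 4 (within the scatter) in this assay and so adds a hydrogen-bond acceptor with no step beyond the scatter. 2-Fluoro-6-methoxyphenyl in place of 2,6-dimethylphenyl gives a number 7 percentage points lower from compound 2 to compound 4 (within the scatter) on the same read-out, so this double change also stays within the scatter. Nothing available bears on the reason for these numbers.

Still open, on these data alone, is whether a hydroxyl group, an amine or a longer alkoxy chain at this position would move stability beyond the scatter. Also open, as far as these compounds go, is whether methoxy behaves alike without the fluoro group on the ring.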